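Trifluoromethoxy in place of fluoro on compound 2

The compounds below may be only part of what the source reports. "The series", "measured", "known", "first", "only" and "open" are said of these compounds alone.

Of the compounds shown here, three have been measured in a functional assay on SEM cells (Homo sapiens) for inhibition, read by MTT assay, with a stated time of 72 h; on this read-out higher numbers stand for weaker inhibition and lower numbers for stronger inhibition. Compound 1 `COc1cc(NC(=O)/C=C/c2cccc(OCc3ccccc3)c2)cc(OC)c1OC` gives 8500 nM, compound 2 `C=C(Br)C(=O)Nc1cccc(/C=C/C(=O)Nc2ccc(F)cc2)c1` gives 8400 nM and compound 3 `C=C(Br)C(=O)Nc1cccc(/C=C/C(=O)Nc2cccc(F)c2)c1` gives 620 nM. Compound 2 therefore sits at the weak end of this small set, level with compound 1 within the scatter and clearly above compound 3.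

The next compound is compound 4 `C=C(Br)C(=O)Nc1cccc(/C=C/C(=O)Nc2ccc(OC(F)(F)F)cc2)c1`. It keeps the core of compound 2 and differs by trifluoromethoxy in place of fluoro on an aromatic carbon, the new group standing on the same aromatic carbon, para to a large group.

Among the measured compounds shown here, only one measured step bears on this change: a 14-fold lower number from compound 2 to compound 3 (1.13 log units; beyond the scatter), a large step that comes from 3-fluorophenyl in place of 4-fluorophenyl on an amide-type nitrogen. It shows that a change on this ring can move the number strongly in this assay. However, it moves the fluoro group rather than replacing it, so neither its size nor its direction carries over directly. For the measured compounds named here, no measured pair covers a replacement at this place, so a much smaller step is expected, leaning only slightly towards stronger inhibition.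

The expected change is a 1.7-fold lower number from compound 2 to compound 4 (0.23 log units; within the scatter). For compound 4 the estimate is 5000 nM, with an expected range of 1500 nM to 15000 nM.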

Compound 4, half-maximal inhibitory concentration: 19300 nM
Beside the measured number, compound 4's estimate is 3.9-fold (0.59 log units) below it; measured number above the stated range.
By their numbers in this assay, from the lowest: compound 3; then compounds 2 and 1 (each within the scatter of the next); then compound 4.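

In this assay the first replacement of the fluoro group at this place, on an aromatic carbon para to a large group, moves towards weaker inhibition (a 2.3-fold higher number from compound 2 to compound 4 (0.36 log units; beyond the scatter)). The earlier step that shifted the fluoro group on this ring (a 14-fold lower number from compound 2 to compound 3 (1.13 log units; beyond the scatter)) went the other way, so changes on this ring can now be read in both directions, with trifluoromethoxy, at 5 heavy atoms and 1 hydrogen-bond acceptor, taking the place of fluoro, at 1 heavy atom and no hydrogen-bond acceptor. No measurement is at hand that would explain this result.

A single replacement cannot separate the contribution of the added oxygen from that of the larger group, so trifluoromethyl or methoxy on the same aromatic carbon would be the informative comparisons, and an amine would test a group of a different kind at this place. As far as these compounds go, it also remains open whether trifluoromethoxy on the ring carbon that carries the fluoro group in compound 3 would follow the same direction as this step or keep the stronger inhibition seen there.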